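The source may report more compounds than this note shows. Statements on the series, on what has been measured and on what is new or still open speak of the compounds shown alone.

Measured so far, in an ADME assay on microsomes from liver (Homo sapiens) for metabolic stability, with a stated time of 10 min; a higher number here means that more of the compound is left, a lower number that less of the compound is left:
- compound 1 `O=C(NS(=O)(=O)c1ccc(F)cc1)c1ccc(Nc2nc(NC3(c4ccc(Cl)cc4)CC3)nc(OCC(F)(F)F)n2)cc1` gives 100%
- compound 2 `CC(C)S(=O)(=O)NC(=O)c1ccc(Nc2nc(NC3(c4ccc(Cl)cc4)CC3)nc(OCC(F)(F)F)n2)cc1` gives 100%
- compound 3 `CC(C)NC(=O)NCCS(=O)(=O)NC(=O)c1ccc(Nc2nc(NC3(c4ccc(Cl)cc4)CC3)nc(OCC(F)(F)F)n2)cc1` gives 100%

Compound 3 thus stands level with compound 1 and compound 2 at the digits shown. Compound 4 `CC(=O)NCCS(=O)(=O)NC(=O)c1ccc(Nc2nc(NC3(c4ccc(Cl)cc4)CC3)nc(OCC(F)(F)F)n2)cc1` differs from compound 3 by methyl in place of isopropylamino on a carbonyl carbon. For the measured compounds named here, every measured step so far changed the group on the sulfonyl sulfur, and each was flat: no change at the digits printed from compound 1 to compound 2 (within the scatter), no change at the digits printed from compound 1 to compound 3 (within the scatter) and no change at the digits printed from compound 2 to compound 3 (within the scatter). The step from compound 2 to compound 3 brought in the whole 2-((isopropylcarbamoyl)amino)ethyl chain, which holds the isopropylamino that now leaves, without moving the number. A step of no size beyond the scatter is therefore expected, no change at the digits printed from compound 3 to compound 4 (within the scatter). For compound 4 the estimate is 100%, with a range from 88% to 100%.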

Compound 4, percent of the compound remaining: 95%
Compound 4: the middle estimate sits 5 percentage points above what was measured; the range from low to high includes it.
By their numbers in this assay, from the lowest: compounds 4, 1, 2 and 3 (each within the scatter of the next).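

In this assay, methyl in place of isopropylamino on the carbonyl carbon gives a number 5 percentage points lower from compound 3 to compound 4 (within the scatter) and stays within the scatter, so this change within the chain, unlike the earlier swaps of the whole group on the sulfonyl sulfur, also leaves the read-out unmoved. The 2-acetamidoethyl group likewise gives a number 5 percentage points lower from compound 2 to compound 4 (within the scatter) and a number 5 percentage points lower from compound 1 to compound 4 (within the scatter) without passing the scatter. Nothing measured here points to a cause. Still open, from the compounds shown here alone, is whether an amine or a carboxylic acid on that carbonyl carbon would move the number beyond the scatter.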